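This account rests on a few compounds, and the source may have more. Where it says the series, first, only, none or still open, it means among the compounds named here.

Compound 1 `COc1ccc(-c2nc3sc(-c4ccccc4)cn3n2)cc1`: 65%
Compound 2 `Clc1ccc(-c2cn3nc(-c4ccccc4)nc3s2)cc1`: 21%

In a functional assay on SK-MEL-5 cells (Homo sapiens) for inhibition, read by sulforhodamine B assay, with a stated time of 48 h, tested at 10 uM (on this read-out lower numbers stand for less inhibition of growth and higher numbers for more inhibition of growth at the one concentration tested), compound 2 gives 21%, the lower of the two numbers and beyond the usual scatter below compound 1. Compound 3 `c1ccc(-c2nc3sc(-c4ccccc4)cn3n2)cc1` differs from compound 2 by one change, hydrogen in place of chloro on an aromatic carbon, turning 4-chlorophenyl to phenyl. For the measured compounds named here, no measured pair shows this change alone, so any forecast is loose. Compound 1 at 65% shows that higher numbers are reachable, so a small upward move is expected, possibly within the scatter. The expected step is a number 9 percentage points higher from compound 2 to compound 3 (within the scatter). For compound 3, the estimate is 30%, with an expected range of 10% to 55%.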

Compound 3, percent growth inhibition at one concentration: 20%
Beside the measured number, compound 3's estimate is 10 percentage points above it; the measured number falls inside the stated range.
By their numbers in this assay, from the lowest: compounds 3 and 2 (each within the scatter of the next); then compound 1.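

With hydrogen in place of chloro, the step is a number 1 percentage points lower from compound 2 to compound 3 (within the scatter), so at this ring position chloro and hydrogen cannot be told apart in this assay. Hydrogen in place of methoxy, on the other aromatic ring, gives a very different result: a number 45 percentage points lower from compound 1 to compound 3 (beyond the scatter), which ties the higher number of compound 1 to methoxy at its own position. No measurement here explains either step. Still open, going by these compounds, is whether methoxy would give a similar number at the position that carries chloro in compound 2, and how an amine or a carboxylic acid would fare at either position.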